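The source may hold more compounds than are shown below. What is called first, only, known or untested is meant among the compounds shown, and "the series" means these compounds.

Of the compounds shown here, three have been measured in a functional assay on the whole organism for inhibition, with Rattus norvegicus as the target, read by paw edema, with stated times of 4 days, 1 h and 2 h, at a dose of 100 mg/kg by the oral route; on this read-out higher numbers stand for more inhibition at the one dose given (going by the name of the read-out) and lower numbers for less inhibition. Compound 1, `CC1CCN(c2nc(-c3ccccc3)nc3ccc(I)cc23)CC1`, gives 56.4%. Compound 2, `CC1CCN(c2nc(-c3ccc(Cl)cc3)nc3ccccc23)CC1`, gives 55.1%. Compound 3, `CC1CCN(c2nc(-c3ccc(Cl)cc3)nc3ccc(Br)cc23)CC1`, gives 55.1%. Among the compounds with values here, the single step between compound 2 and compound 3, bromo in place of hydrogen on an aromatic carbon, gave no change at the digits printed from compound 2 to compound 3 (within the scatter), so adding that bromo made no difference that can be trusted. Compound 3 thus stands level with compound 2, and compound 1 sits within the scatter of both, so the three measured numbers cannot be told apart.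

The compound still to be measured is compound 4, `CC1CCN(c2nc(-c3ccc(Cl)cc3)nc3ccc(I)cc23)CC1`. It differs from compound 3 in one place: iodo in place of bromo on an aromatic carbon. Within the data shown here, no measured pair shows iodo exchanged directly for bromo. Among the measured compounds shown here, the one step that bears on this position, the exchange of hydrogen for bromo in no change at the digits printed from compound 2 to compound 3 (within the scatter), stayed within the scatter, and compound 1, which carries iodo at this position, also lies within the scatter of compound 3. Swapping one halogen for another at the same spot is therefore expected to give a number 0.1 percentage points lower from compound 3 to compound 4 (within the scatter) in this assay, that is, no change beyond the scatter. Compound 4 is accordingly estimated at 55%, with a likely range from 45% to 65%.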

Compound 4, a percentage reported as inhibition, in the whole organism at one dose (the size of the read-out at that dose, not a potency): 45.8%
Beside the measured number, compound 4's estimate is 9.2 percentage points above it, within the range that was stated.
By their numbers in this assay, from the lowest: compounds 4, 2, 3 and 1 (each within the scatter of the next, the first and the last beyond it).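

In this assay, the halogen position on the shared core can now be read with iodo as well: iodo in place of bromo gives a number 9.3 percentage points lower from compound 3 to compound 4 (within the scatter) and iodo in place of hydrogen gives a number 9.3 percentage points lower from compound 2 to compound 4 (within the scatter) in the compounds that carry chloro. Both steps stay inside the usual scatter, so even with iodo, no halogen at this position can yet be said to alter the inhibition. Within the data shown here, the only step to pass the scatter lies at a different place: chloro in place of hydrogen, with iodo held at this position, gives a number 10.6 percentage points lower from compound 1 to compound 4 (beyond the scatter) and is modest, which separates compound 4 from compound 1 but from no other compound.

On these data alone, it remains open whether that chloro step would also appear with bromo or hydrogen at the halogen position, and what a methoxy group, an amine or a carboxylic acid would do at that position. No accompanying measurement accounts for any of these steps.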